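The source may report more compounds than this note shows. Statements on the series, on what has been measured and on what is new or still open speak of the compounds shown alone.

Working notes on the series in an assay on isolated protein for binding affinity to Leucine-rich repeat serine/threonine-protein kinase 2 variant G2019S (Homo sapiens), read by TR-FRET and LanthaScreen, with a stated time of 2 h; a lower number here means a stronger inhibitor, a higher number a weaker inhibitor. Among the compounds with values here, compound 1 `Cc1cn(C)nc1Nc1cc2c(c(N)n1)c(C#N)c(N1CCC[C@H]1C)n2C` gives 75 nM and compound 2 `C[C@@H]1CCCN1c1c(C#N)c2c(N)nc(Nc3cnn(C)c3)cc2n1C` gives 794 nM; the one measured step, an 11-fold higher number from compound 1 to compound 2 (1.02 log units; beyond the scatter), alters a group that compound 3 does not carry. Compound 3 `Cn1c(NCc2ccccc2)c(C#N)c2c(N)ncnc21` gives 243 nM, the second highest of the three numbers, beyond the scatter from both compound 1 and compound 2. Compound 4 `Cn1c(NCc2ccccc2F)c(C#N)c2c(N)ncnc21` differs from compound 3 by fluoro in place of hydrogen on an aromatic carbon. Within the data shown here, no measured step bears on this change, and the shift from compound 1 to compound 2 offers no guide to it, so the expectation is a step of a 1.2-fold lower number from compound 3 to compound 4 (0.08 log units; within the scatter) at most, not beyond the scatter. Compound 4 is therefore estimated at 200 nM, with a range of 70 nM to 600 nM.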

Compound 4, inhibition constant: 120 nM
For compound 4 the middle estimate is 1.7-fold (0.22 log units) above the measured one; the measured number falls inside the stated range.
By their numbers in this assay, from the lowest: compounds 1 and 4 (each within the scatter of the next); then compound 3; then compound 2.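

In this assay, within the data shown here, the first measured step on this ring, phenyl to 2-fluorophenyl, gives a 2.0-fold lower number from compound 3 to compound 4 (0.31 log units; beyond the scatter), a modest change but beyond the scatter. Fluoro on an aromatic carbon ortho to a large group is thus enough to shift the number, and in the lower direction. Nothing on hand explains this step. Open, on these data alone, is how chloro or methoxy in place of this fluoro would read, and how fluoro elsewhere on the ring would read. The step also says nothing about compounds lacking this ring, such as compound 1.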